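Expecting Little Change from Compound 3 to Compound 4

This account rests on a few compounds, and the source may have more. Where it says the series, first, only, none or still open, it means among the compounds named here.

Compound 1 `Cc1ncc([N+](=O)[O-])n1CCSc1nnc(-c2ccccc2N)o1`: 20100 nM
Compound 2 `Cc1ncc([N+](=O)[O-])n1CCSc1nnc(-c2ccc(N)cc2)o1`: 19800 nM
Compound 3 `Cc1ncc([N+](=O)[O-])n1CCSc1nnc(-c2ccccc2Cl)o1`: 22500 nM

All three values come from a functional assay on MCF7 cells (Homo sapiens) for cytotoxicity, read by MTT assay, with a stated time of 48 h; a lower number here means a stronger inhibitor, a higher number a weaker inhibitor. Compound 3, at 22500 nM, cannot be told apart from the other two compounds, with a 1.1-fold higher number from compound 1 to compound 3 (0.05 log units; within the scatter) and a 1.1-fold higher number from compound 2 to compound 3 (0.06 log units; within the scatter). The unmeasured compound 4 `Cc1ccc(-c2nnc(SCCn3c([N+](=O)[O-])cnc3C)o2)c(O)c1` carries 2-hydroxy-4-methylphenyl in place of 2-chlorophenyl on an aromatic carbon. The same place was varied in the measured compounds, and those steps are the relevant evidence. Alongside the two steps to compound 3, there is a 1.0-fold lower number from compound 1 to compound 2 (0.01 log units; within the scatter). All three stayed within the scatter, and none of these compounds goes against that. However, none of them carries 2-hydroxy-4-methylphenyl, so the evidence is indirect and the range is kept wide. The expected change is a 1.1-fold lower number from compound 3 to compound 4 (0.05 log units; within the scatter), which means no expected step beyond the scatter. The estimated value for compound 4 is 20000 nM, with an expected range of 11000 nM to 37000 nM.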

Compound 4, half-maximal inhibitory concentration: 23500 nM
Beside the measured number, compound 4's estimate is 1.2-fold (0.07 log units) below it; measured number inside the range.
By their numbers in this assay, from the lowest: compounds 2, 1, 3 and 4 (each within the scatter of the next).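

In this assay, 2-hydroxy-4-methylphenyl in place of 2-chlorophenyl gives a 1.0-fold higher number from compound 3 to compound 4 (0.02 log units; within the scatter), while the comparisons with the aminophenyl compounds give a 1.2-fold higher number from compound 2 to compound 4 (0.07 log units; within the scatter) and a 1.2-fold higher number from compound 1 to compound 4 (0.07 log units; within the scatter). The earlier compounds tested only amino and chloro on the phenyl ring; compound 4 shows that hydroxy and methyl together, with the hydrogen-bond donor and acceptor counted for this group and absent from 2-chlorophenyl, also leave the number within the scatter, and no listed compound goes against this. No measurement shown here offers an explanation for this flat response.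

All the groups shown at this carbon are substituted phenyl rings, so it remains open whether cyclohexyl, or a carboxylic acid on the phenyl ring, would move the number beyond the scatter. The compounds also leave open whether a longer chain between the sulfur and the nitro-bearing ring would do so.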